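Phenylsulfonyl at the ring nitrogen: expected cytotoxicity of compound 4

This account rests on a few compounds, and the source may have more. Where it says the series, first, only, none or still open, it means among the compounds named here.

The measured compounds, all read in an ADME assay on MT4 cells (Homo sapiens) for cytotoxicity, read by MTT assay, with a stated time of 4 days; on this read-out higher numbers stand for lower toxicity in this test and lower numbers for higher toxicity in this test:
Compound 1, `Cc1ccc(-c2c(C)c(-c3ccc(C)c(C)c3)c(C(OC(C)(C)C)C(=O)O)c(C)c2NC(=O)c2ccccc2)cc1C`, gives 9100 nM.
Compound 2, `CCC(=O)Nc1c(C)c(C(OC(C)(C)C)C(=O)O)c(-c2ccc(C)c(C)c2)c(C)c1-c1ccc(C)c(C)c1`, gives 15000 nM.
Compound 3, `CNc1c(C)c(C(OC(C)(C)C)C(=O)O)c(-c2ccc(C)c(C)c2)c(C)c1-c1ccc(C)c(C)c1`, gives 8800 nM.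

Compound 3 sits level with the other two in this assay: the step of a 1.0-fold lower number from compound 1 to compound 3 (0.01 log units; within the scatter) and the step of a 1.7-fold lower number from compound 2 to compound 3 (0.23 log units; within the scatter) are both within the scatter, so no order among the three can be read from these numbers.

The next compound, compound 4, `Cc1ccc(-c2c(C)c(-c3ccc(C)c(C)c3)c(C(OC(C)(C)C)C(=O)O)c(C)c2NS(=O)(=O)c2ccccc2)cc1C`, differs from compound 3 in one place: phenylsulfonyl in place of methyl on a nitrogen on an aromatic ring. Every measured step in this set changes the group on that same nitrogen. Benzoyl to propanoyl, a 1.6-fold higher number from compound 1 to compound 2 (0.22 log units; within the scatter), and benzoyl to methyl, a 1.0-fold lower number from compound 1 to compound 3 (0.01 log units; within the scatter), and propanoyl to methyl, a 1.7-fold lower number from compound 2 to compound 3 (0.23 log units; within the scatter), all stayed within the scatter, although benzoyl, like phenylsulfonyl, carries a six-membered aromatic ring. On that record the move from methyl to phenylsulfonyl is expected to leave this assay unchanged beyond the scatter, and the expected step is a 1.1-fold higher number from compound 3 to compound 4 (0.06 log units; within the scatter). Compound 4 is therefore estimated at 10000 nM, with a range from 4000 nM to 25000 nM.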

Compound 4, half-maximal cytotoxic concentration: 11000 nM
Compound 4: the middle estimate sits 1.1-fold (0.04 log units) below what was measured; measured number inside the range.
By their numbers in this assay, from the lowest: compounds 3, 1, 4 and 2 (each within the scatter of the next).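

In this assay the step of a 1.3-fold higher number from compound 3 to compound 4 (0.10 log units; within the scatter) for phenylsulfonyl in place of methyl, the step of a 1.4-fold lower number from compound 2 to compound 4 (0.13 log units; within the scatter) for phenylsulfonyl in place of propanoyl and the step of a 1.2-fold higher number from compound 1 to compound 4 (0.08 log units; within the scatter) for phenylsulfonyl in place of benzoyl all stay within the scatter. The earlier compounds shown here had covered only methyl and two groups joined through a carbonyl, so this result extends the flat record at the nitrogen on the aromatic ring to a group joined through sulfur, one that enters with 9 heavy atoms, one six-membered aromatic ring and 2 hydrogen-bond acceptors. Across these four compounds, no substituent on this nitrogen separates from any other in this test, and nothing available explains that flatness.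

The compounds shown leave open whether a free amino group, a carboxylic acid or a longer alkyl chain on this nitrogen would move the number beyond the scatter. They also leave open whether a fluorine or a methoxy group on the phenyl ring of the phenylsulfonyl would do so, and whether changes elsewhere on the shared core would matter more than changes at this nitrogen.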